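The source may report more compounds than this note shows. Statements on the series, on what has been measured and on what is new or still open speak of the compounds shown alone.

Compound 2 `COc1ccc(OC)c(/C=C/C(=O)N/N=C/c2ccc(Cl)cc2)c1` gives the lower of the two numbers recorded in a functional assay on SK-OV-3 cells (Homo sapiens) for antiproliferative activity, read by sulforhodamine B assay, with a stated time of 48 h (on this read-out higher numbers stand for weaker inhibition of growth and lower numbers for stronger inhibition of growth), at 149 nM. Within the data shown here, compound 1 `COc1ccc(OC)c(/C=C/c2nnc(Nc3ccc(Cl)cc3)o2)c1` gives 2790 nM in this assay, a gap beyond the usual scatter, though the two structures differ in more than one place and no single step links them. Compound 3 `COc1ccc(OC)c(/C=C/C(=O)N/N=C/c2ccccc2)c1` differs from compound 2 by one change: hydrogen in place of chloro on an aromatic carbon. Among the measured compounds shown here, no measured pair shows this change, so only a modest move toward weaker inhibition is expected, and the step of a 1.7-fold higher number from compound 2 to compound 3 (0.24 log units; within the scatter) is expected to sit near the edge of the scatter. Compound 3 is therefore estimated at 260 nM, within a range from 90 nM to 750 nM.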

Compound 3, concentration for 50% growth inhibition: 12000 nM
Beside the measured number, compound 3's estimate is 46-fold (1.66 log units) below it; the measured number lies above the stated range.
By their numbers in this assay, from the lowest: compound 2; then compound 1; then compound 3.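

In this assay, the change from 4-chlorophenyl to phenyl gives an 81-fold higher number from compound 2 to compound 3 (1.91 log units; beyond the scatter), so a single chloro on this aromatic carbon, para to a large group, carries much of the growth inhibition seen with compound 2. Compounds 1 and 2 both hold this chloro, so neither could show how much depends on it. No available measurement explains the size of this step. The compounds shown leave open whether fluoro, bromo or an amine at this place would keep the number near that of compound 2, and whether the same change would move the core of compound 1 as far.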